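The source may hold more compounds than are shown below. What is called first, only, known or untested is meant among the compounds shown, and "the series" means these compounds.

Measured so far:
compound 1 `Clc1ccc(Cc2nn3c(Br)c(-c4ccc(Cl)cc4)nc3s2)cc1` — in a functional assay on L1210 cells (Mus musculus) for cytotoxicity, with a stated time of 48 h (on this read-out lower numbers stand for stronger inhibition and higher numbers for weaker inhibition), compound 1 gives a limit, > 250000 nM.
compound 2 `N#CSc1c(-c2ccc(Cl)cc2)nc2sc(Cc3ccc(Cl)cc3)nn12` — in this assay compound 2 gives 49000 nM.

Going by the values given here, the one measured step, an at least 5.1-fold lower number from compound 1 to compound 2 (0.70 log units; beyond the scatter), is at least modest. Compound 2 thus holds the only number shown, while the other value is a limit.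

Compound 3 `N#CSc1c(-c2ccccc2)nc2sc(Cc3ccc(Cl)cc3)nn12` differs from compound 2 by hydrogen in place of chloro on an aromatic carbon. Among the compounds with values here, no measured step covers this change, since the known step concerns the cyanosulfanyl group instead. For compound 3 the expected result in this assay is 49000 nM, between 15000 nM and 160000 nM, a step of no change at the digits printed from compound 2 to compound 3 (within the scatter) expected to stay within the scatter.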

Compound 3, half-maximal inhibitory concentration: 24000 nM
Compound 3: the middle estimate sits 2.0-fold (0.31 log units) above what was measured; the measured number falls inside the stated range.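

The earlier step concerned the cyanosulfanyl group, whereas this one shows that the chloro of the 4-chlorophenyl group is not required for activity in this assay: phenyl gives a 2.0-fold lower number from compound 2 to compound 3 (0.31 log units; beyond the scatter), a modest gain. Within this pair, the place on the aromatic ring therefore responds to a change, with the simpler group giving the lower number. Nothing available gives a cause for this step.

The compounds shown leave open how a methoxy group, an amine or a carboxylic acid would read at this place. They also leave open whether the remaining chloro responds in the same way.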